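The source may report more compounds than this note shows. Statements on the series, on what has been measured and on what is new or still open speak of the compounds shown alone.

Compound 1 `CC1(C)O[C@@H](CO)[C@H](Cn2cc(Cn3c4c(c5ccccc53)C(=O)c3c[n+]([O-])c5ccccc5c3C4=O)nn2)O1`: 370 nM in a functional assay on A549 cells (Homo sapiens) for cytotoxicity, read by MTT assay, with a stated time of 72 h; on this read-out higher numbers stand for weaker inhibition and lower numbers for stronger inhibition
Compound 2 `CN(C)CCCCn1c2c(c3ccccc31)C(=O)c1c[n+]([O-])c3ccccc3c1C2=O`: 310 nM
Compound 3 `CC1(C)OC[C@H](Cn2cc(Cn3c4c(c5ccccc53)C(=O)c3c[n+]([O-])c5ccccc5c3C4=O)nn2)O1`: 340 nM

All three measured compounds share the same core and differ only in the chain on the aromatic nitrogen. In this assay compound 2 gives the lowest of the three numbers, yet compound 3 and compound 1 both sit within the scatter of it, so the three cannot be ordered. Going by the values given here, the one measured step, a 1.1-fold lower number from compound 1 to compound 3 (0.04 log units; within the scatter), concerns the saturated ring of compound 1 and compound 3 and tells nothing about the amine end of the chain.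

Compound 4 `O=C1c2c[n+]([O-])c3ccccc3c2C(=O)c2c1c1ccccc1n2CCN1CCCCC1` arises from compound 2 by a change at the chain end: piperidin-1-yl in place of 2-(dimethylamino)ethyl on a saturated chain carbon, two bonds along the chain from an aromatic nitrogen. Among the compounds with values here, no measured step bears on this exchange; the data offer only the observation that three quite different chains give numbers within the scatter of one another. The expectation is therefore a step of no change at the digits printed from compound 2 to compound 4 (within the scatter), that is, no step beyond the scatter. Compound 4 is estimated at 310 nM in this assay, with a range from 150 nM to 650 nM.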

Compound 4, half-maximal inhibitory concentration: 1080 nM
Estimate against measurement, compound 4: 3.5-fold (0.54 log units) below; measured number outside the range, above it.
By their numbers in this assay, from the lowest: compounds 2, 3 and 1 (each within the scatter of the next); then compound 4.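

In this assay the end of the chain turns out to matter: a 3.5-fold higher number from compound 2 to compound 4 (0.54 log units; beyond the scatter) is the first step beyond the scatter among the compounds shown, and it comes with piperidin-1-yl in place of 2-(dimethylamino)ethyl on a saturated chain carbon, two bonds along the chain from an aromatic nitrogen. The entering group brings a six-membered non-aromatic ring, while the counts of hydrogen-bond donors and acceptors are the same on both sides, so those counts do not separate the two groups. Nothing at hand accounts for the step.

The same difference also reads 4-(dimethylamino)butyl to 2-(piperidin-1-yl)ethyl, which leaves open whether the step goes with the ring or with the shorter chain. A 4-(piperidin-1-yl)butyl chain or a 2-(dimethylamino)ethyl chain on the aromatic nitrogen would tell these two apart.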